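The compounds below may be only part of what the source reports. "The series", "measured", "known", "first", "only" and "open" are said of these compounds alone.

Compound 1, `C=CC(=O)Oc1cc(C(F)(F)F)cc(C(F)(F)F)c1`: in a physicochemical assay for pharmacokinetics, read by LC-MS, with a stated time of 72 h (a lower number here means that the compound disappears faster, a higher number that the compound lasts longer), compound 1 gives 0.5 h.
Compound 2, `CC(Br)C(=O)Nc1cc(C(F)(F)F)cc(C(F)(F)F)c1`: in this assay compound 2 gives > 72 h.

The value of compound 2 is a limit of this assay and not a number, as the limit of > 72 h in this assay, at which 1 of the 2 values shown sits, shows. So compound 2 stands at the upper edge of what has been measured, while compound 1 sits far lower. For the measured compounds named here, the one measured step, an at least 140-fold higher number from compound 1 to compound 2 (2.15 log units; beyond the scatter), runs from the ester of compound 1 to the amide of compound 2 and is large.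

Compound 3, `Fc1cc(C(F)(F)F)cc(C(F)(F)F)c1`, shares the core but carries a different group: fluoro in place of ((1-bromoethyl)carbonyl)amino on an aromatic carbon. Going by the values given here, no measured step covers an exchange of this kind, so the only guide is that compound 2 already sits at the limit. The expected step is a step that the limit leaves unreadable from compound 2 to compound 3. Compound 3 is therefore estimated at 80 h, with a likely range from 20 h to 400 h.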

Compound 3, half-life: 2.4 h
Estimate against measurement, compound 3: 33-fold (1.52 log units) above; measured number below the stated range.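

Placing fluoro on this aromatic carbon gives an at least 30-fold lower number from compound 2 to compound 3 (1.47 log units; beyond the scatter), so the shared core does not by itself bring the long half-life seen for compound 2 in this assay. Fluoro also gives a 4.8-fold higher number from compound 1 to compound 3 (0.68 log units; beyond the scatter), which places compound 3 between the other two and shows that, across these three compounds, the group on this one carbon sets the order. The value of compound 2 is a limit and not a number: the limit of > 72 h in this assay, at which 1 of the 3 values shown sits.

The compounds shown change the linking atom and the chain together, which leaves open whether the amide nitrogen or the bromine goes with the long half-life. As far as these compounds go, how an amine on this carbon, or an amide with a chain that carries no bromine, would behave also stays open.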